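Replacing the aryl ester on the thioether arm

The source may report more compounds than this note shows. Statements on the series, on what has been measured and on what is new or still open speak of the compounds shown alone.

Measured so far:
compound 1, `N#Cc1c(N)nc(SCc2ccn[nH]2)c(C#N)c1-c1ccc(OCC2CC2)cc1`, 552 nM
compound 2, `COC(=O)c1cccc(CSc2nc(N)c(C#N)c(-c3ccc(OCC4CC4)cc3)c2C#N)c1`, 66 nM

Among these two, compound 2 holds the lowest number in an assay on CHO cells for displacement of a labelled ligand from adenosine receptor A1 (Homo sapiens), read by scintillation counting, with a stated time of 90 min; on this read-out higher numbers stand for weaker inhibition and lower numbers for stronger inhibition. Among the measured compounds shown here, the single measured step, an 8.4-fold lower number from compound 1 to compound 2 (0.92 log units; beyond the scatter), changed the same position that is altered here. Compound 3, `N#Cc1c(N)nc(SCC(=O)NO)c(C#N)c1-c1ccc(OCC2CC2)cc1`, differs from compound 2 by hydroxycarbamoyl in place of 3-(methoxycarbonyl)phenyl on a saturated chain carbon bound to a sulfur. For the measured compounds named here, no measured compound carries a group like hydroxycarbamoyl, so the direction rests on the modest size of that one step alone. Compound 3 is expected to give a higher number, a step of about a 6.1-fold higher number from compound 2 to compound 3 (0.78 log units; beyond the scatter). The estimated value for compound 3 is 400 nM, within 100 nM to 2000 nM.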

Compound 3, inhibition constant: 536 nM
Compound 3: the middle estimate sits 1.3-fold (0.13 log units) below what was measured; low and high end bracket the measured number.
By their numbers in this assay, from the lowest: compound 2; then compounds 3 and 1 (each within the scatter of the next).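

In this assay the move to hydroxycarbamoyl gave an 8.1-fold higher number from compound 2 to compound 3 (0.91 log units; beyond the scatter) and so, like 1H-pyrazol-5-yl, this much smaller group on a saturated chain carbon bound to a sulfur stays well short of 3-(methoxycarbonyl)phenyl. The other comparison, a 1.0-fold lower number from compound 1 to compound 3 (0.01 log units; within the scatter), leaves hydroxycarbamoyl and 1H-pyrazol-5-yl indistinguishable, though the two groups share little in form. The compounds shown leave open whether the lower number of compound 2 belongs to its aromatic ring or to its methyl ester, which a plain benzyl or a carboxylic acid on that ring would separate. Nothing measured here gives a reason for either step.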